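Shortening the Side Chain in a Spiro Amide Series

The compounds below may be only part of what the source reports. "The series", "measured", "known", "first", "only" and "open" are said of these compounds alone.

Compound 1 `CC(C)(C)OC(=O)NCCCCCNC(=O)CN1CN(c2ccccc2)C2(CCN(C(=O)c3ccc(C(C)(C)C)cc3)CC2)C1=O`: 13700 nM
Compound 2 `COC(=O)CCCNC(=O)CN1CN(c2ccccc2)C2(CCN(C(=O)c3ccc(C4CCCCC4)cc3)CC2)C1=O`: 2500 nM
Compound 3 `CC(C)(C)OC(=O)NCNC(=O)CN1CN(c2ccccc2)C2(CCN(C(=O)c3ccc(C4CCCCC4)cc3)CC2)C1=O`: 1700 nM

In an assay on HEK293 cells for displacement of a labelled ligand from NPC1-like intracellular cholesterol transporter 1 (Homo sapiens) (a lower number here means a stronger inhibitor, a higher number a weaker inhibitor), compound 1 stands at the highest of the three numbers; compound 2 lies nearest to it and compound 3 furthest, both gaps beyond the scatter. Compound 4 `CC(C)(C)c1ccc(C(=O)N2CCC3(CC2)C(=O)N(CC(=O)NCNS(C)(=O)=O)CN3c2ccccc2)cc1` differs from compound 1 by methanesulfonamido in place of 4-((tert-butoxycarbonyl)amino)butyl on a saturated chain carbon bound to an amide-type nitrogen. Within the data shown here, the only measured step touching the same part of the molecule is a 1.5-fold lower number from compound 2 to compound 3 (0.17 log units; within the scatter), which is the sole guide here. Because a 1.5-fold lower number from compound 2 to compound 3 (0.17 log units; within the scatter) stayed within the scatter, no step beyond the scatter is expected in this assay, and a 1.2-fold lower number from compound 1 to compound 4 (0.10 log units; within the scatter) is the anticipated outcome. Compound 4 is therefore estimated at 11000 nM, with a range from 3500 nM to 35000 nM.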

Compound 4, half-maximal inhibitory concentration: 3200 nM
For compound 4 the middle estimate is 3.4-fold (0.54 log units) above the measured one; the measured number lies below the stated range.
By their numbers in this assay, from the lowest: compounds 3, 2 and 4 (each within the scatter of the next); then compound 1.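

In this assay the swap of 4-((tert-butoxycarbonyl)amino)butyl for methanesulfonamido on a saturated chain carbon bound to an amide-type nitrogen gives a 4.3-fold lower number from compound 1 to compound 4 (0.63 log units; beyond the scatter) and so moves the number beyond the scatter, which the earlier step at this place, a 1.5-fold lower number from compound 2 to compound 3 (0.17 log units; within the scatter), did not do. The exchange takes 12 heavy atoms down to 5 while the hydrogen-bond donor and acceptor counts stay the same. Nothing measured here accounts for the result.

The change alters the chain and its end group together, so their separate shares remain unresolved. On these data alone, whether an amine or a carboxylic acid on a chain of this place would track with methanesulfonamido also stays open.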